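The compounds below may be only part of what the source reports. "The series", "measured", "known", "first", "only" and "open" are said of these compounds alone.

Measured so far:
- Compound 1, `CN1CCN(c2ccc(S(=O)(=O)Oc3cccc(Cl)c3)cc2)C1=O`: 2200 nM
- Compound 2, `CCN1CCN(c2ccc(S(=O)(=O)Oc3cccc(Cl)c3)cc2)C1=O`: 5400 nM
- Compound 3, `CCCN1CCN(c2ccc(S(=O)(=O)Oc3ccccc3C)cc2)C1=O`: > 100000 nM

All three were tested in a functional assay on MCF7 cells (Homo sapiens) for antiproliferative activity, read by sulforhodamine B assay, with a stated time of 48 h; on this read-out higher numbers stand for weaker inhibition and lower numbers for stronger inhibition. Compound 1 and compound 2 share one core and differ only by methyl in place of hydrogen on a saturated chain carbon bound to an amide-type nitrogen in a ring. That change gave a 2.5-fold higher number from compound 1 to compound 2 (0.39 log units; beyond the scatter), so the added methyl made inhibition somewhat weaker.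

Compound 3 belongs to a different core; the difference between the two cores is not broken down here. In this assay compound 3 gives only a limit, > 100000 nM, not a number. It stands at the limit of > 100000 nM in this assay, at which 1 of the 3 values shown sits.

Compound 4, `CCCN1CCN(c2ccc(S(=O)(=O)Oc3ccccc3CC)cc2)C1=O`, has not yet been measured. It differs from compound 3 by methyl in place of hydrogen on a saturated chain carbon bound to an aromatic carbon. Among the compounds with values here, this is the same kind of change as the one from compound 1 to compound 2, but not the same: there the place was a saturated chain carbon bound to an amide-type nitrogen in a ring, here it is a saturated chain carbon bound to an aromatic carbon. The earlier step is therefore only a loose guide.

The expected step is a step that the limit leaves unreadable from compound 3 to compound 4, because compound 3 already sits at the limit of > 100000 nM in this assay, at which 1 of the 3 values shown sits, and a single added methyl is unlikely to move a compound back from that limit into the measurable range. Compound 4 is estimated at 150000 nM. Its expected range runs from 30000 nM to 600000 nM.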

Compound 4, half-maximal inhibitory concentration: 2300 nM
Compound 4: the middle estimate sits 65-fold (1.81 log units) above what was measured, and the stated range ends above it.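

In this assay compound 3 gives > 100000 nM, which is a limit of the assay and not a number. Putting a methyl in place of a hydrogen on a saturated chain carbon bound to an aromatic carbon, which turns 2-methylphenyl into 2-ethylphenyl, gave an at least 43-fold lower number from compound 3 to compound 4 (1.63 log units; beyond the scatter), so inhibition became far stronger, whereas the earlier methyl step made it somewhat weaker, and this kind of change therefore did not carry over from one core to the other in size or in direction: the same change on two cores in this assay, a 2.5-fold higher number (0.39 log units; beyond the scatter) from compound 1 to compound 2 and an at least 43-fold lower number (1.63 log units; beyond the scatter) from compound 3 to compound 4, at least 100-fold (2.02 log units) apart, beyond the scatter of two such steps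

This does not show what lies behind the gap, since the two steps differ both in their core and in the place of the methyl, and each rests on a single pair of compounds, so the data cannot separate the two differences, and the step to compound 4 gives only a lower bound on its size.

Going by these compounds, it remains open whether the same 2-methylphenyl to 2-ethylphenyl change would give a similar step on the core of compound 1. On these data alone, it also remains open how a propyl chain in place of the ethyl of compound 4 would read in this assay.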